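Swapping the Ring on the Amide Nitrogen of Compound 3

A few compounds are considered here, and "the series" means these few. Any claim that something is new, unique, unknown or untested is made for them only; others in the source may bear on it.

Three compounds share one core and differ only in the group carried on an amide-type nitrogen. Compound 1 `CNC(=O)c1ccncc1Nc1cc(-c2ccc3ccn(C)c3c2)c2nccnc2c1` carries a methyl there and, in an assay for inhibition of 6-phosphofructo-2-kinase/fructose-2,6-bisphosphatase 3 (Homo sapiens), read by ADP-Glo, with a stated time of 2 h (a higher number here means a weaker inhibitor, a lower number a stronger inhibitor), compound 1 gives 83 nM. Compound 2 `Cn1cc(NC(=O)c2ccncc2Nc2cc(-c3ccc4ccn(C)c4c3)c3nccnc3c2)cn1` carries a 1-methyl-1H-pyrazol-4-yl instead, and in this assay compound 2 gives 33 nM. Compound 3 `CN1CCC(NC(=O)c2ccncc2Nc2cc(-c3ccc4ccn(C)c4c3)c3nccnc3c2)CC1` carries a 1-methylpiperidin-4-yl, and in this assay compound 3 gives 38 nM. Among the three numbers compound 3 stands second highest, close to compound 2 and further from compound 1.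

Compound 4 `Cn1ccc2ccc(-c3cc(Nc4cnccc4C(=O)NC4CCNC(=O)C4)cc4nccnc34)cc21` has not yet been measured. It differs from compound 3 in one place: 2-oxopiperidin-4-yl in place of 1-methylpiperidin-4-yl on an amide-type nitrogen.

Among the measured compounds shown here, two measured steps bear on this change. Replacing methyl with a ring group gave a 2.5-fold lower number from compound 1 to compound 2 (0.40 log units; beyond the scatter) and a 2.2-fold lower number from compound 1 to compound 3 (0.34 log units; beyond the scatter), both modest. Exchanging one ring group for another gave a 1.2-fold higher number from compound 2 to compound 3 (0.06 log units; within the scatter), within the scatter. The move from compound 3 to compound 4 is again an exchange of one ring group for another of the same size on the same nitrogen, so a step within or only just beyond the scatter is expected, with no clear direction. Compound 4 is therefore estimated at 50 nM, with a range from 20 nM to 130 nM, which would mean an expected step of a 1.3-fold higher number from compound 3 to compound 4 (0.12 log units; within the scatter).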

Compound 4, half-maximal inhibitory concentration: 69 nM
Beside the measured number, compound 4's estimate is 1.4-fold (0.14 log units) below it, and the stated range covers the measured number.
By their numbers in this assay, from the lowest: compounds 2, 3, 4 and 1 (each within the scatter of the next, the first and the last beyond it).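

On this amide-type nitrogen, 2-oxopiperidin-4-yl replaces 1-methylpiperidin-4-yl, a six-membered non-aromatic ring with 1 hydrogen-bond donor in place of one with 0 hydrogen-bond donors, and this assay shows a 1.8-fold higher number from compound 3 to compound 4 (0.26 log units; within the scatter) so this exchange alone cannot be told apart from repeat-to-repeat variation. The new compound does, however, give the first gap between two ring groups at this position that clears the scatter, with a 2.1-fold higher number from compound 2 to compound 4 (0.32 log units; beyond the scatter) so ring groups here are not all equivalent, even though compound 2 and compound 3 could not be separated. Nor does a ring in place of methyl always pay off: compound 2 and compound 3 each moved beyond the scatter from compound 1, but compound 4 goes against that pattern, with a 1.2-fold lower number from compound 1 to compound 4 (0.08 log units; within the scatter) and so remains unresolved from the small methyl compound.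

No supporting measurement accompanies these numbers to explain the differences among these groups. Still open, from the compounds shown here alone, is how a piperidin-4-yl with a free ring amine, a 1-methyl-2-oxopiperidin-4-yl or an open chain such as 2-methoxyethyl would read on the same nitrogen.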